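Ether to Thioether Swap on a Shared Core

The compounds below may be only part of what the source reports. "The series", "measured", "known", "first", "only" and "open" are said of these compounds alone.

Compound 1 `Nc1cc(N)c2nc(-c3ccccc3)c(Oc3ccc(Cl)c(Cl)c3)nc2c1` — 89100 nM
Compound 2 `CCOC(=O)[C@H](CCC(=O)O)NC(=O)c1ccc(Sc2nc3cc(N)cc(N)c3nc2-c2ccccc2)cc1` — < 100000 nM

Among the measured compounds shown here, in a functional assay on SK-MEL-2 cells (Homo sapiens) for inhibition, read by sulforhodamine B assay, with a stated time of 48 h (a lower number here means that less compound is tolerated, a higher number that more compound is tolerated), compound 1 gives 89100 nM, the only plain number among the measured compounds. For compound 2 the entry < 100000 nM is a limit of the assay, not a number; it is the case counted in the limit of < 100000 nM in this assay, at which 1 of the 2 values shown sits. Compound 3 `Nc1cc(N)c2nc(-c3ccccc3)c(Sc3ccc(Cl)c(Cl)c3)nc2c1` has not been measured yet. It differs from compound 1 by (3,4-dichlorophenyl)sulfanyl in place of 3,4-dichlorophenoxy on an aromatic carbon. For the measured compounds named here, no measured pair shows this change, so the expected step in this assay is a 1.1-fold lower number from compound 1 to compound 3 (0.05 log units; within the scatter), small enough to sit within the usual scatter. For compound 3 the estimate is 80000 nM, between 30000 nM and 200000 nM.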

Compound 3, concentration lethal to 50% of the cells: < 100000 nM
Compound 3: only a limit was reported; the forecaster's own chance of this, stated with the estimate: 35%; the middle value is on the limit's open side.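

Among the compounds shown here, for compound 3 the entry < 100000 nM is a limit, not a number, and no step from compound 1 to compound 3 can be read. From the compounds shown here alone, whether (3,4-dichlorophenyl)sulfanyl in place of 3,4-dichlorophenoxy shifts the value in this assay stays open.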